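Swapping Cyclohexyl for Nitrophenoxy on a Shared Core

The source may hold more compounds than are shown below. What is called first, only, known or untested is meant among the compounds shown, and "the series" means these compounds.

Of the compounds shown here, three built on one shared core have been tested in a functional assay on KOPN-8 cells (Homo sapiens) for antiproliferative activity, with a stated time of 72 h; on this read-out lower numbers stand for an effect already at smaller amounts and higher numbers for an effect only at larger amounts of compound. Compound 1 `COC(=O)c1cc(=O)c2c(OC)cc(OC)cc2n1S(=O)(=O)c1ccc(C)cc1`, whose core carries an ester and a sulfonyl group rather than an amide, gives 6000 nM in this assay. Compound 2 `COc1cc(OC)c2c(=O)cc(C(=O)Nc3ccc(C4CCCCC4)cc3)[nH]c2c1`, an amide whose attached phenyl ring bears a cyclohexyl group, gives 18400 nM in this assay. Among the two compounds that yielded an actual number, compound 2 stands highest, and compound 1, its nearest neighbour, sits below it by a gap that goes beyond the usual scatter. Compound 3 `COc1cc(OC)c2c(=O)cc(C(=O)Nc3ccc4oc(-c5ccc(F)cc5)nc4c3)[nH]c2c1`, whose amide carries a larger aromatic substituent, is reported in this assay only as a limit, > 36700 nM, rather than a number; this is the limit of > 36700 nM in this assay, at which 1 of the 3 values shown sits.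

Compound 4 `COc1cc(OC)c2c(=O)cc(C(=O)Nc3ccc(Oc4ccc([N+](=O)[O-])cc4)cc3)[nH]c2c1` has not yet been measured. Relative to compound 2 the change is 4-nitrophenoxy in place of cyclohexyl on an aromatic carbon. For the measured compounds named here, no pair of measured compounds differs in just one place, so there is no directly comparable step to lean on. The step from compound 2 to compound 4 in this assay is expected to be a 1.2-fold higher number from compound 2 to compound 4 (0.08 log units; within the scatter), a modest shift toward higher numbers that may not clear the scatter. Compound 4 is therefore estimated to give 22000 nM in this assay, with a plausible range from 7000 nM to 40000 nM.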

Compound 4, half-maximal effective concentration: 20500 nM
Compound 4: the middle estimate sits 1.1-fold (0.03 log units) above what was measured; low and high end bracket the measured number.
By their numbers in this assay, from the lowest: compound 1; then compounds 2 and 4 (each within the scatter of the next). At a limit, above all of these: compound 3.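

In this assay, putting 4-nitrophenoxy in place of cyclohexyl on this aromatic carbon gives a 1.1-fold higher number from compound 2 to compound 4 (0.05 log units; within the scatter), so the two compounds cannot be told apart. For the compounds shown here, this is the first comparison that changes only one place, and it shows that this position accepts two quite different groups with no measurable difference in the read-out: a non-aromatic carbon ring with no hydrogen-bond acceptors, and a group with more heavy atoms, an aromatic ring and hydrogen-bond acceptors. Nothing measured here gives a property of either group that would bear on this result.

Both groups shown at this position contain a six-membered ring of carbon, so it remains open whether a much smaller or differently built group, such as an amine or a carboxylic acid on the same aromatic carbon, would give a clearly different number. Going by these compounds alone, it is also unclear whether the nitro group matters within 4-nitrophenoxy, since no compound here carries the phenoxy group without it, and a single step cannot show whether this tolerance extends to other changes on the shared core.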